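Butyl for cyclohexyl on the core of compound 1

The source may hold more compounds than are shown below. What is called first, only, known or untested is meant among the compounds shown, and "the series" means these compounds.

For the measured compounds named here, compound 1 `N[C@H]1CC[C@H](Nc2nc(Nc3ccc(Cl)cc3)c3ncn(C4CCCCC4)c3n2)CC1` gives 9100 nM in a functional assay on HCC827 cells (Homo sapiens) for inhibition, read by fluorescence, with a stated time of 72 h (on this read-out higher numbers stand for weaker inhibition of growth and lower numbers for stronger inhibition of growth), the lower of the two numbers measured so far; the nearest neighbour, compound 2 `N[C@H]1CC[C@H](Nc2nc(Nc3ccc(O)cc3)c3ncn(C4CCCCC4)c3n2)CC1`, gives 32500 nM, a step of a 3.6-fold higher number from compound 1 to compound 2 (0.55 log units; beyond the scatter) that changes a group on the aromatic ring rather than on the core nitrogen. Compound 3 `CCCCn1cnc2c(Nc3ccc(Cl)cc3)nc(N[C@H]3CC[C@H](N)CC3)nc21` differs from compound 1 as follows: butyl in place of cyclohexyl on an aromatic nitrogen. Going by the values given here, no measured step touches the group on the aromatic nitrogen, so the hydroxy-for-chloro step from compound 1 to compound 2 does not bear on it, and nothing supports a direction. The expected step in this assay from compound 1 to compound 3 is therefore a 1.3-fold higher number from compound 1 to compound 3 (0.12 log units; within the scatter), a change not clearly beyond the scatter. For compound 3 the expected value is 12000 nM, within a range of 3500 nM to 45000 nM.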

Compound 3, concentration for 50% growth inhibition: 10800 nM
Beside the measured number, compound 3's estimate is 1.1-fold (0.05 log units) above it; measured number inside the range.
By their numbers in this assay, from the lowest: compounds 1 and 3 (each within the scatter of the next); then compound 2.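

Working from this assay, the first measured step at the aromatic nitrogen is a 1.2-fold higher number from compound 1 to compound 3 (0.07 log units; within the scatter), so cyclohexyl and butyl cannot be told apart at this position. For this pair, the six-membered non-aromatic ring is not needed to keep the number in the range of compound 1: the open butyl chain, with no ring, reads the same within the scatter. This rests on a single pair, and nothing on hand bears on why the two groups read alike.

Still open, on these data alone, is whether a methyl group, a branched isopropyl group, or a butyl chain ending in an amine or a carboxylic acid on the same nitrogen would move the number beyond the scatter. Also open, as far as these compounds go, is whether hydroxy in place of chloro on the aromatic carbon gives a comparable step when butyl sits on the nitrogen.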